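A few compounds are considered here, and "the series" means these few. Any claim that something is new, unique, unknown or untested is made for them only; others in the source may bear on it.

Measured in an ADME assay on microsomes from liver (Rattus norvegicus) for metabolic stability, read by HPLC, using NADPH, with stated times of 5 min and 60 min, tested at 10 uM; a lower number here means slower removal, a higher number faster removal of the compound:
compound 1 `CCS(=O)(=O)Nc1ccc(Oc2ccccc2)c(-c2cn(C)c(=O)c3[nH]ccc23)c1`: 3330 mL/min/kg
compound 2 `Cn1cc(-c2cc(C(N)=O)ccc2Oc2ccccc2)c2cc[nH]c2c1=O`: 550 mL/min/kg
compound 3 `Cn1cc(-c2cc(NS(C)(=O)=O)ccc2Oc2cccnc2)c2cc[nH]c2c1=O`: 350 mL/min/kg

Compound 1 has the highest of these three numbers in this assay, and compound 2 and compound 3 both lie well under it. The next compound, compound 4 `CCS(=O)(=O)Nc1ccc(OC2CCN(C)CC2)c(-c2cn(C)c(=O)c3[nH]ccc23)c1`, comes from compound 1 by one change: 1-methylpiperidin-4-yl in place of phenyl on an oxygen on an aromatic ring. Within the data shown here, no measured step covers this change. The nearest evidence is a 6.1-fold lower number from compound 1 to compound 2 (0.78 log units; beyond the scatter), a modest step made at a different place, with carbamoyl in place of (ethylsulfonyl)amino. It bears only indirectly, so a step of similar modest size, towards a lower number, is expected here. The expected step is a 3.0-fold lower number from compound 1 to compound 4 (0.48 log units; beyond the scatter). For compound 4 the estimated clearance is 1100 mL/min/kg, with an expected range of 350 mL/min/kg to 3300 mL/min/kg.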

Compound 4, clearance: 80 mL/min/kg
Estimate against measurement, compound 4: 14-fold (1.14 log units) above; measured number below the stated range.
By their numbers in this assay, from the lowest: compound 4; then compounds 3 and 2 (each within the scatter of the next); then compound 1.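

In this assay, the change from phenoxy to (1-methylpiperidin-4-yl)oxy gives a 42-fold lower number from compound 1 to compound 4 (1.62 log units; beyond the scatter), a large step. It shows that the group on this oxygen strongly affects the clearance, and that this single change outweighs the modest step seen earlier at a different place. Nothing measured here accounts for the size of this step.

The compounds shown leave open whether the step follows the ring nitrogen or the loss of the aromatic ring, which a cyclohexyl or an unmethylated piperidin-4-yl group on the same oxygen would separate. They also leave open whether the change carries over to a compound with carbamoyl in place of (ethylsulfonyl)amino.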